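This account rests on a few compounds, and the source may have more. Where it says the series, first, only, none or still open, it means among the compounds named here.

For the measured compounds named here, compound 2 `CC(C)[C@H](C(=O)Nc1cccnn1)c1ccc(Cl)cc1` is the only member of this pair with a number in a functional assay on CHO cells for agonist activity at Free fatty acid receptor 2 (Homo sapiens), read by cAMP accumulation (a higher number here means a weaker inhibitor, a lower number a stronger inhibitor), where compound 2 gives 2300 nM. Compound 1 `CC(C)[C@H](C(=O)NCc1ccccc1)c1ccc(Cl)cc1` reaches only a limit in this assay, > 100000 nM. Going by the values given here, the one measured step is therefore an at least 43-fold lower number from compound 1 to compound 2 (1.63 log units; beyond the scatter), with one end sitting at the limit of > 100000 nM in this assay, at which 1 of the 2 values shown sits. Compound 3 `CC(C)[C@H](C(=O)Nc1ccon1)c1ccc(Cl)cc1` differs from compound 2 by 1,2-oxazol-3-yl in place of pyridazin-3-yl on an amide-type nitrogen. Both partners here carry a heteroaryl on the amide nitrogen, so the benzyl-to-pyridazinyl step speaks only loosely to this change; a small shift, at most slightly beyond the scatter, is expected in this assay. The expected step is a 1.7-fold higher number from compound 2 to compound 3 (0.24 log units; within the scatter). For compound 3 the estimate is 4000 nM, ranging from 1500 nM to 15000 nM.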

Compound 3, half-maximal inhibitory concentration: 36000 nM
For compound 3 the middle estimate is 9.0-fold (0.95 log units) below the measured one; the measured number lies above the stated range.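

On the amide-type nitrogen, the choice of heteroaryl matters in this assay: the two rings have equal counts of hydrogen-bond donors and acceptors but are not interchangeable, with a 16-fold higher number from compound 2 to compound 3 (1.19 log units; beyond the scatter). The 1,2-oxazol-3-yl group still gives a lower number than benzyl, with an at least 2.7-fold lower number from compound 1 to compound 3 (0.44 log units; beyond the scatter). That step is only a bound, since compound 1 stands at a limit of the assay: the limit of > 100000 nM in this assay, at which 1 of the 3 values shown sits.

The two heteroaryl rings differ in both ring size and hetero atoms, and the compounds shown do not separate these two differences. As far as these compounds go, how a pyrimidine or thiazole ring on the same nitrogen would read in this assay remains open.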